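The source may hold more compounds than are shown below. What is called first, only, known or untested is meant among the compounds shown, and "the series" means these compounds.

In an ADME assay on SH-SY5Y cells (Homo sapiens) for cytotoxicity, read by MTT assay, with a stated time of 48 h (a higher number here means a weaker inhibitor, a lower number a stronger inhibitor), compound 1 (`COc1ccc(C(=O)/C=C/c2ccc(C(=O)O)cc2)c(O)c1`) gives > 100000 nM, which is a limit of the assay and not a number. Compound 2 (`COc1ccc(C(=O)/C=C/c2cc(OC)c(OC)c(OC)c2)c(O)c1`) gives > 100000 nM in this assay, which is likewise a limit. Among the measured compounds shown here, the whole record so far is therefore (the limit of > 100000 nM in this assay, at which 2 of the 2 values shown sit), and it contains no measured step.

Compound 3 (`COc1ccc(C(=O)/C=C/c2ccc(C(=O)NCc3ccccc3)cc2)c(O)c1`) has not yet been measured. It differs from compound 1 at a single place, on a carbonyl carbon whose other neighbour is an aromatic carbon, with benzylamino in place of hydroxy on a carbonyl carbon.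

For the measured compounds named here, with no measured step to draw on, a modest shift towards a lower number is expected in this assay, and the reading may again be only a limit. This expectation starts from compound 1 at > 100000 nM. The estimated change is an at least 1.6-fold lower number from compound 1 to compound 3 (0.22 log units; that floor lies within the scatter). For compound 3 the expected value is 60000 nM. The estimated range for compound 3 runs from 20000 nM to 100000 nM.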

Compound 3, half-maximal inhibitory concentration: > 100000 nM
Compound 3 gave a limit, no number (the forecaster's own chance of this, stated with the estimate: 50%); middle value at least 1.6-fold (0.22 log units) from the limit.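

In this assay compound 3 gives > 100000 nM, which is a limit of the assay and not a number. No step can be read from compound 1 to compound 3 because both stand at a limit: the limit of > 100000 nM in this assay, at which 3 of the 3 values shown sit. The compounds shown leave open whether any of them has a measurable half-maximal inhibitory concentration in this assay, and how they would rank.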